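Shortened ether side chain on the shared core

A few compounds are considered here, and "the series" means these few. Any claim that something is new, unique, unknown or untested is made for them only; others in the source may bear on it.

Compound 1 `Nc1ccc2cccc(OCC3CCCO3)c2n1` carries an (oxolan-2-yl)methyl ether on the shared core. In an assay on cells with melanin-concentrating hormone receptor 1 (Homo sapiens) as the target, read by radioligand binding (a lower number here means a stronger inhibitor, a higher number a weaker inhibitor), compound 1 gives only a limit, > 2000 nM, so no number is available for it. Compound 2 `CC(CC(C)(C)C)Oc1cccc2ccc(N(C)C)nc12` differs from compound 1 in both the ether and the amine. In this assay compound 2 likewise gives only a limit, > 2000 nM. Among the compounds with values here, both values shown sit at the limit of > 2000 nM in this assay, at which 2 of the 2 values shown sit; the measured pair therefore sets no scale for any step, and no trend in this assay can be read from it. Compound 3 `Nc1ccc2cccc(OCC3CC3)c2n1` differs from compound 1 as follows: cyclopropyl in place of oxolan-2-yl on a saturated chain carbon bound to an oxygen on an aromatic ring. With compound 1 at the limit, the direction of this change in this assay is open; the expectation is that compound 3 stays near the limit, with no step beyond the scatter resolvable. Compound 3 is expected at 3000 nM, range 800 nM to 10000 nM. The expected step is a step that the limit leaves unreadable from compound 1 to compound 3.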

Compound 3, half-maximal inhibitory concentration: > 2000 nM
Compound 3: no number, only a limit; the forecaster's own chance of this, stated with the estimate: 70%; the middle value does not contradict the limit.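

No step from compound 1 to compound 3 can be read, since both give only limits: the limit of > 2000 nM in this assay, at which 3 of the 3 values shown sit.

In this assay the compounds shown leave open whether any change to the ether or the amine on the shared core gives a value rather than a limit.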